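The compounds below may be only part of what the source reports. "The series", "measured", "known", "first", "only" and "open" are said of these compounds alone.

Measured compounds:
- compound 1, `COc1ccc(OCCCCCN2CCCC(COC(=O)c3ccccc3N3C(=O)CC(C)C3=O)C2)cc1OC`: 8320 nM
- compound 2, `O=C(OCC1CCN(C(=O)CCc2ccccc2)CC1)c1ccccc1-c1ccccc1`: 5900 nM
- compound 3, `C[C@H]1CC(=O)N(c2ccccc2C(=O)OC[C@H]2CCCN(CCCc3ccccc3)C2)C1=O`: 10500 nM

These values come from an in vitro functional assay on HEK ts201 cells for antagonist activity at Neuronal acetylcholine receptor; alpha4/beta2 (Homo sapiens), read by fluorescence and calcium flux; a lower number here means a stronger inhibitor, a higher number a weaker inhibitor. Compound 1 gives 8320 nM, and this number lies within the usual scatter of the values of compound 3 and of compound 2, so the three compounds cannot be told apart on these data. Compound 4, `CC1CC(=O)N(c2ccccc2C(=O)OCC2CCCN(CCCCCOc3ccccc3)C2)C1=O`, has not been measured. It differs from compound 1 in one place: phenyl in place of 3,4-dimethoxyphenyl on an oxygen on a saturated carbon. For the measured compounds named here, no two measured compounds differ in only one place, so no earlier step shows how such a change moves the number. The change is expected to make a step no larger than the scatter, a 1.1-fold higher number from compound 1 to compound 4 (0.03 log units; within the scatter). On that basis compound 4 is estimated at 9000 nM, in the range 4000 nM to 20000 nM.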

Compound 4, half-maximal inhibitory concentration: 17000 nM
Beside the measured number, compound 4's estimate is 1.9-fold (0.28 log units) below it; low and high end bracket the measured number.
By their numbers in this assay, from the lowest: compounds 2, 1, 3 and 4 (each within the scatter of the next, the first and the last beyond it).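

In this assay, for the compounds shown here, phenyl in place of 3,4-dimethoxyphenyl on an oxygen on a saturated carbon gives a 2.0-fold higher number from compound 1 to compound 4 (0.31 log units; beyond the scatter) and is the first single change here that can be read. The group at this position does affect the number: plain phenyl goes with a weaker inhibitor, though the step only just clears the usual scatter. Nothing available explains the step.

On these data alone, whether a single methoxy group would be enough, or a hydroxy group or chlorine would serve as well, stays open. This single pair also cannot show whether the step would repeat on other compounds.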